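Swapping the hexyl tail for a hydroxyphenyl ring

The source may report more compounds than this note shows. Statements on the series, on what has been measured and on what is new or still open speak of the compounds shown alone.

Measured so far:
compound 1 `CCCCCC/C=C/C[C@H]1C[C@@H]([C@@H](O)c2ccccc2)CO[C@@H]1c1ccccc1`: 4990 nM
compound 2 `Oc1ccccc1/C=C/C[C@H]1C[C@@H]([C@@H](O)c2ccccc2)CO[C@@H]1c1ccccc1`: 10800 nM

Both numbers come from a functional assay on HL-60 cells (Homo sapiens) for cytotoxicity, read by WST assay, with a stated time of 48 h; a higher number here means a weaker inhibitor, a lower number a stronger inhibitor. Within the data shown here, compound 1 has the lowest of the two numbers, and its only neighbour is compound 2, which sits at a 2.2-fold higher number from compound 1 to compound 2 (0.34 log units; beyond the scatter). That step replaces the hexyl chain with a 2-hydroxyphenyl ring at the same spot.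

Compound 3 `Oc1ccc(/C=C/C[C@H]2C[C@@H]([C@@H](O)c3ccccc3)CO[C@@H]2c2ccccc2)cc1` has not been tested yet. It differs from compound 1 in one place: 4-hydroxyphenyl in place of hexyl on a double-bonded chain carbon bound to a double-bonded chain carbon. This is closely related to the measured step, since both exchange the hexyl chain for a hydroxyphenyl ring on a double-bonded chain carbon bound to a double-bonded chain carbon, the ring differing only in where its hydroxyl sits.

Among the measured compounds shown here, because the one comparable change gave a 2.2-fold higher number from compound 1 to compound 2 (0.34 log units; beyond the scatter), a modest move toward a higher number in this assay is expected here too, of roughly a 1.9-fold higher number from compound 1 to compound 3 (0.28 log units; within the scatter). Compound 3 is therefore estimated to give about 9500 nM, with a likely range from 3500 nM to 26000 nM.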

Compound 3, half-maximal inhibitory concentration: 7380 nM
Compound 3: the middle estimate sits 1.3-fold (0.11 log units) above what was measured; measured number inside the range.
By their numbers in this assay, from the lowest: compounds 1, 3 and 2 (each within the scatter of the next, the first and the last beyond it).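

In this assay, the 4-hydroxyphenyl ring gives a 1.5-fold higher number from compound 1 to compound 3 (0.17 log units; within the scatter), so on this double-bonded chain carbon, this ring cannot be told apart from the hexyl chain it replaces, even though the 2-hydroxyphenyl ring stood clear of the scatter. Changing only the ring isomer gives a 1.5-fold lower number from compound 2 to compound 3 (0.17 log units; within the scatter), which is also within the scatter, so compound 3 cannot be separated from either neighbour, and these numbers give no firm sign that the place of the hydroxyl matters on its own. No measurement is available to explain any of these small differences.

The compounds shown leave open whether a plain phenyl ring, with no hydroxyl at all, would give a number close to those of the two hydroxyphenyl rings, and so whether the hydroxyl matters or the ring alone is enough. They also leave open how a longer chain, or a ring carrying an amine or a carboxylic acid, would read at this same place.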